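From dichlorobenzyl ether back to a fluorobenzyl ether

The compounds below may be only part of what the source reports. "The series", "measured", "known", "first", "only" and "open" are said of these compounds alone.

Among the measured compounds shown here, in a functional assay on HT-29 cells (Homo sapiens) for inhibition, read by MTT assay, with a stated time of 48 h (on this read-out lower numbers stand for stronger inhibition and higher numbers for weaker inhibition), compound 2 `Cc1ccc(NC(=O)NC(=O)c2ccc(OCc3ccc(Cl)c(Cl)c3)cc2)cc1-c1nc2ccccc2[nH]1` gives 1030 nM, the lowest of the two numbers so far. For the measured compounds named here, compound 1 `Cc1ccc(NC(=O)NC(=O)c2ccc(OCc3cccc(F)c3)cc2)cc1-c1nc2ccccc2[nH]1` gives 38200 nM; the only measured step is a 37-fold lower number from compound 1 to compound 2 (1.57 log units; beyond the scatter), a large one. Compound 3 `Cc1ccc(NC(=O)NC(=O)c2ccc(OCc3ccc(F)cc3)cc2)cc1-c1nc2ccccc2[nH]1` carries 4-fluorophenyl in place of 3,4-dichlorophenyl on a saturated chain carbon bound to an oxygen on an aromatic ring. From the compounds shown here alone, that change undoes most of what separated compound 1 from compound 2, so a large rise is expected, though the 4-fluorophenyl of compound 3 is untested and may not behave like the 3-fluorophenyl of compound 1. Compound 3 is therefore estimated at 15000 nM, between 3000 nM and 60000 nM, an expected step of a 15-fold higher number from compound 2 to compound 3 (1.16 log units; beyond the scatter).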

Compound 3, half-maximal inhibitory concentration: 980 nM
Estimate against measurement, compound 3: 15-fold (1.18 log units) above, outside the stated range (below it).
By their numbers in this assay, from the lowest: compounds 3 and 2 (each within the scatter of the next); then compound 1.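

In this assay, the change to 4-fluorophenyl gives a 1.1-fold lower number from compound 2 to compound 3 (0.02 log units; within the scatter), so at this place a single fluorine serves as well as the two chlorines. The step of a 39-fold lower number from compound 1 to compound 3 (1.59 log units; beyond the scatter) is large, although both compounds carry one fluorine, so the high number of compound 1 goes with the 3-fluorophenyl and not with fluorine as such. Nothing at hand gives a reason for this. Still open, from the compounds shown here alone, is where a 3-chlorophenyl or a 4-chlorophenyl would fall at this place. Also open, going by these compounds, is how a carboxylic acid or an amine on the benzyl ring would read.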